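Aryl versus pyrimidinyl on the ring nitrogen: cytotoxicity notes

The compounds below may be only part of what the source reports. "The series", "measured", "known", "first", "only" and "open" are said of these compounds alone.

Measured in an ADME assay on RAW264.7 cells (Mus musculus) for cytotoxicity, read by MTT assay, with a stated time of 48 h, tested at 50 uM; on this read-out lower numbers stand for less inhibition and higher numbers for more inhibition at the one concentration tested (going by the name of the read-out):
- compound 1 `N=C1S/C(=C\c2ccc(OCc3ccccc3)cc2)C(=O)N1c1cccc([N+](=O)[O-])c1`: 52.9%
- compound 2 `Cc1c(Cl)cccc1N1C(=N)S/C(=C\c2ccc(OCc3ccccc3)cc2)C1=O`: 59.7%
- compound 3 `N=C1S/C(=C\c2ccc(OCc3ccccc3)cc2)C(=O)N1c1ncccn1`: 26.6%

Compound 3 stands lowest of the three numbers. Its nearest neighbour is compound 1, with a number 26.3 percentage points lower from compound 1 to compound 3 (beyond the scatter) separating them; its furthest is compound 2, with a number 33.1 percentage points lower from compound 2 to compound 3 (beyond the scatter). Compound 1 and compound 2, both carrying a carbon-only aryl on the ring nitrogen, sit close together: a number 6.8 percentage points higher from compound 1 to compound 2 (within the scatter).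

Compound 4 `Cc1ccc(C)c(N2C(=N)S/C(=C\c3ccc(OCc4ccccc4)cc3)C2=O)c1` is not yet measured. It differs from compound 3 in one place: 2,5-dimethylphenyl in place of pyrimidin-2-yl on an amide-type nitrogen in a ring. The two steps that bear on this are the ones in which pyrimidin-2-yl replaced a carbon-only aryl, and both lowered the read-out beyond the scatter, one modestly (a number 26.3 percentage points lower from compound 1 to compound 3 (beyond the scatter)) and one by a large amount (a number 33.1 percentage points lower from compound 2 to compound 3 (beyond the scatter)). Reversing that direction, the estimate is a rise of comparable size back into the range of compound 1 and compound 2: the expected step is a number 28.4 percentage points higher from compound 3 to compound 4 (beyond the scatter). Compound 4 is therefore expected to give about 55%, within a range from 40% to 70%.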

Compound 4, a percentage reported as inhibition, at one concentration (the size of the read-out at that concentration, not a potency): 45.8%
For compound 4 the middle estimate is 9.2 percentage points above the measured one; measured number inside the range.
By their numbers in this assay, from the lowest: compound 3; then compounds 4, 1 and 2 (each within the scatter of the next, the first and the last beyond it).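

In this assay, a third carbon-only aryl, 2,5-dimethylphenyl, also stands clear of the pyrimidin-2-yl on the amide-type nitrogen, with a number 19.2 percentage points higher from compound 3 to compound 4 (beyond the scatter), so the low number of compound 3 now stands against three carbon-only aryls. These aryls are not interchangeable at this position: a number 13.9 percentage points lower from compound 2 to compound 4 (beyond the scatter), while a number 7.1 percentage points lower from compound 1 to compound 4 (within the scatter), so the groups carried on the aryl can themselves move the read-out, though by less than the largest step away from pyrimidin-2-yl. No measurement on hand accounts for these steps.

Open, as far as these compounds go, is whether pyridin-2-yl, with a single ring nitrogen, would stay near compound 3 or join the carbon-only aryls. Also open, from the compounds shown here alone, is how an unsubstituted phenyl, or a phenyl bearing an amine or a carboxylic acid, would read at this position.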